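Working notes: 3-methyl-1,2-oxazol-5-yl in place of methylcarbamoyl

This account rests on a few compounds, and the source may have more. Where it says the series, first, only, none or still open, it means among the compounds named here.

Compound 1 `CCN(CC)S(=O)(=O)c1ccc(S(=O)(=O)N2CCC[C@@H](C(=O)N(C)C(C)C)C2)cc1`: in a functional assay on MIA PaCa-2 cells (Homo sapiens) for inhibition, read by MTT assay, with a stated time of 3 days (a lower number here means a stronger inhibitor, a higher number a weaker inhibitor), compound 1 gives 1400 nM.
Compound 2 `CCN(CC)C(=O)[C@@H]1CCCN(S(=O)(=O)c2ccc(S(=O)(=O)N(CC)CC)cc2)C1`: in this assay compound 2 gives 700 nM.
Compound 3 `CCN(CC)S(=O)(=O)c1ccc(S(=O)(=O)N2CCC[C@@H](C(=O)NC)C2)cc1`: in this assay compound 3 gives 2000 nM.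

Compound 3 stands at the highest of the three numbers. Its nearest neighbour is compound 1, seen in a 1.4-fold higher number from compound 1 to compound 3 (0.15 log units; within the scatter); the step of a 2.9-fold higher number from compound 2 to compound 3 (0.46 log units; beyond the scatter) is beyond the scatter, so compound 3 is the weakest point in this small set. Compound 4 `CCN(CC)S(=O)(=O)c1ccc(S(=O)(=O)N2CCC[C@@H](c3cc(C)no3)C2)cc1` is not yet measured. It differs from compound 3 as follows: 3-methyl-1,2-oxazol-5-yl in place of methylcarbamoyl on a saturated ring carbon. The three measured steps all concern the substituents on the amide nitrogen and keep the carbonyl in place; a 2.0-fold lower number from compound 1 to compound 2 (0.30 log units; within the scatter) and a 1.4-fold higher number from compound 1 to compound 3 (0.15 log units; within the scatter) lie within the scatter, and only a 2.9-fold higher number from compound 2 to compound 3 (0.46 log units; beyond the scatter) goes beyond it. None of them exchanges the whole methylcarbamoyl group for an aromatic ring, so they bear on the change to compound 4 only in showing that variation at this carbon has so far stayed within a modest span. In this assay, going by the values given here, a step of the size a 1.3-fold lower number from compound 3 to compound 4 (0.12 log units; within the scatter) is expected, in neither direction beyond the scatter, with a wide range because no direct precedent exists for (3-methyl-1,2-oxazol-5-yl in place of methylcarbamoyl on a saturated ring carbon). Compound 4 is therefore estimated at 1500 nM, between 500 nM and 5000 nM.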

Compound 4, half-maximal inhibitory concentration: 2700 nM
Estimate against measurement, compound 4: 1.8-fold (0.26 log units) below, and the stated range covers the measured number.
By their numbers in this assay, from the lowest: compounds 2, 1, 3 and 4 (each within the scatter of the next, the first and the last beyond it).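

In this assay the whole methylcarbamoyl group, amide hydrogen and carbonyl included, gives way on the saturated ring carbon to 3-methyl-1,2-oxazol-5-yl, a five-membered aromatic ring, with the number staying within the scatter (a 1.4-fold higher number from compound 3 to compound 4 (0.13 log units; within the scatter)), so at this position in this series the amide is exchangeable without a step that can be read as a change. The same holds against the isopropyl(methyl)carbamoyl group (a 1.9-fold higher number from compound 1 to compound 4 (0.29 log units; within the scatter)), whereas the diethylcarbamoyl group of compound 2 stands apart from the new ring by a step beyond the scatter, though a modest one (a 3.9-fold higher number from compound 2 to compound 4 (0.59 log units; beyond the scatter)), so the one clear separation at this carbon still runs from compound 2 to the others. No data at hand bear on why the numbers fall as they do.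

Open, going by these compounds, is whether a carboxylic acid, an aminomethyl group or a longer chain on this ring carbon would stay in the same span of numbers. Also open, on these data alone, is whether the methyl on the 1,2-oxazole counts at all, which the unsubstituted 1,2-oxazol-5-yl ring or a phenyl ring in its place would show.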